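The source may hold more compounds than are shown below. What is called first, only, known or untested is meant among the compounds shown, and "the series" means these compounds.

Measured compounds in a functional assay on PC-3 cells (Homo sapiens) for cytotoxicity, read by sulforhodamine B assay; a higher number here means a weaker inhibitor of growth, a lower number a stronger inhibitor of growth:
- compound 2, `COc1cccc(COc2ccccc2OCCNCCOc2c(OC)cccc2OC)c1`: 15100 nM
- compound 1, `COc1cccc(OC)c1OCCNCCOc1ccccc1OCc1ccccc1[N+](=O)[O-]`: 34700 nM

Compound 2 holds the lower of the two numbers, the gap being a 2.3-fold lower number from compound 1 to compound 2 (0.36 log units; beyond the scatter). Compound 3, `COc1ccc(COc2ccccc2OCCNCCOc2c(OC)cccc2OC)cc1`, differs from compound 2 by 4-methoxyphenyl in place of 3-methoxyphenyl on a saturated chain carbon bound to an oxygen on an aromatic ring. Among the measured compounds shown here, the single measured step, a 2.3-fold lower number from compound 1 to compound 2 (0.36 log units; beyond the scatter), swaps a 2-nitrophenyl for a 3-methoxyphenyl and so concerns a different exchange; it offers no direct guide for shifting the methoxy group from the 3- to the 4-position. For the measured compounds named here, with no step bearing on the change, no shift beyond the scatter in this assay is expected. Compound 3 is estimated at 15000 nM, within 6000 nM to 40000 nM, meaning a 1.0-fold lower number from compound 2 to compound 3 (0.00 log units; within the scatter).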

Compound 3, concentration for total growth inhibition: 34700 nM
Compound 3: the middle estimate sits 2.3-fold (0.36 log units) below what was measured, within the range that was stated.
By their numbers in this assay, from the lowest: compound 2; then compounds 1 and 3 (each within the scatter of the next).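

Exchanging 3-methoxyphenyl for 4-methoxyphenyl on a saturated chain carbon bound to an oxygen on an aromatic ring is not a silent change in this assay (a 2.3-fold higher number from compound 2 to compound 3 (0.36 log units; beyond the scatter)). Set against 2-nitrophenyl, 4-methoxyphenyl shows no change at the digits printed from compound 1 to compound 3 (within the scatter), so the lower number of compound 2 goes with 3-methoxyphenyl and not with methoxyphenyl groups in general. Nothing measured on these compounds accounts for the difference between the two methoxy placements. Still open, as far as these compounds go, is how 2-methoxyphenyl, 3-ethoxyphenyl or 3-hydroxyphenyl would read at this place.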